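Swapping a chloro for a methoxy on the benzyl ring

The source may report more compounds than this note shows. Statements on the series, on what has been measured and on what is new or still open speak of the compounds shown alone.

Of the compounds shown here, three built on one shared core have been tested in a functional assay on PC-3 cells (Homo sapiens) for cytotoxicity, read by MTT assay; a lower number here means a stronger inhibitor, a higher number a weaker inhibitor. Compound 1 `COc1ccc2cc([C@H](C)c3nnc(SCc4ccc(C)cc4)n3-c3ccc(Cl)cc3)ccc2c1` gives 8400 nM. Compound 3 `COc1ccc2cc([C@H](C)c3nnc(SCc4ccc(Cl)cc4)n3-c3ccc(Cl)cc3)ccc2c1` gives 5800 nM, the lowest of the three numbers; its nearest neighbour is compound 1, and the step of a 1.4-fold lower number from compound 1 to compound 3 (0.16 log units; within the scatter) lies within the scatter. Compound 2 `COc1ccc(CSc2nnc([C@@H](C)c3ccc4cc(OC)ccc4c3)n2-c2ccc(F)cc2)cc1` gives 400000 nM, a number far higher than that of compound 3.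

Compound 4 `COc1ccc(CSc2nnc([C@@H](C)c3ccc4cc(OC)ccc4c3)n2-c2ccc(Cl)cc2)cc1` has not yet been measured. It differs from compound 3 in one place: methoxy in place of chloro on an aromatic carbon. Going by the values given here, no measured step exchanges chloro for methoxy directly. Among the compounds with values here, the one single change that has been measured, methyl to chloro, gave a 1.4-fold lower number from compound 1 to compound 3 (0.16 log units; within the scatter), a step within the scatter. Compound 2 carries the same 4-methoxybenzyl group as compound 4, though with a fluoro instead of a chloro on the other aromatic ring, and its value in this assay is by far the highest seen. On that basis a large upward step, a 21-fold higher number from compound 3 to compound 4 (1.32 log units; beyond the scatter), is expected. Compound 4 is therefore estimated at 120000 nM, with a range from 20000 nM to 500000 nM.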

Compound 4, half-maximal inhibitory concentration: <= 400000 nM
Compound 4 was reported as a limit; the forecaster's own chance of this, stated with the estimate: 20%; the middle value is on the limit's open side.
By their numbers in this assay, from the lowest: compounds 3 and 1 (each within the scatter of the next); then compound 2.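

In this assay compound 4 gives <= 400000 nM, which is a limit and not a number. The steps to compound 4 from compound 1 and from compound 3 cannot be read, so replacing 4-chlorobenzyl with 4-methoxybenzyl still has no measured size, and the result adds only a ceiling for this compound: the limit of <= 400000 nM in this assay, at which 1 of the 4 values shown sits. Exchanging fluoro for chloro on the other aromatic ring gives a number no higher from compound 2 to compound 4 (the limit leaves the size open), which gives a direction but no size.

From the compounds shown here alone, it remains open how far the number moves when methoxy replaces chloro on the benzyl ring, or whether it rises at all. Going by these compounds, it is also open what a group of another kind in that place, such as an amine or a carboxylic acid, would do to the number.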